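The source may hold more compounds than are shown below. What is called first, only, known or untested is meant among the compounds shown, and "the series" means these compounds.

In a functional assay on SK-BR-3 cells (Homo sapiens) for antiproliferative activity (a lower number here means a stronger inhibitor, a higher number a weaker inhibitor), two compounds sharing one core have been measured so far. Compound 1 `CO[C@@H]1[C@@H](O)[C@@H](O)[C@H](Oc2ccc3cc(NC(=O)C4CC4)c(=O)oc3c2C)OC1(C)C`, with cyclopropyl on a carbonyl carbon, gives 517000 nM, and compound 2 `CCCCCC(=O)Nc1cc2ccc(O[C@@H]3OC(C)(C)[C@H](OC)[C@@H](O)[C@H]3O)c(C)c2oc1=O`, with pentyl in that place, gives 84000 nM. Compound 2 therefore holds the lower of the two numbers and is the stronger inhibitor of the pair.

Compound 3 `CCCC(=O)Nc1cc2ccc(O[C@@H]3OC(C)(C)[C@H](OC)[C@@H](O)[C@H]3O)c(C)c2oc1=O` shortens the chain of compound 2: hydrogen in place of ethyl on a saturated chain carbon, three bonds along the chain from a carbonyl carbon. This is hydrogen in place of ethyl on a saturated chain carbon, three bonds along the chain from a carbonyl carbon, which can also be read as pentyl to propyl. Among the compounds with values here, only one measured step bears on this change, a 6.2-fold lower number from compound 1 to compound 2 (0.79 log units; beyond the scatter). It is modest and replaces cyclopropyl rather than trimming a straight chain, so it offers only indirect guidance. Propyl is expected to give back part of that step, moving toward a higher number in this assay. The expected step is a 2.3-fold higher number from compound 2 to compound 3 (0.35 log units; beyond the scatter), which would be smaller than the measured one. For compound 3, the estimated value is 190000 nM, within an expected range of 80000 nM to 450000 nM.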

Compound 3, half-maximal inhibitory concentration: 313000 nM
The estimate for compound 3 lay 1.6-fold (0.22 log units) below the measured number; measured number inside the range.
By their numbers in this assay, from the lowest: compound 2; then compounds 3 and 1 (each within the scatter of the next).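

Trimming pentyl to propyl on this carbonyl carbon does more than give back a small part of the earlier gain: in this assay the step is (a 3.7-fold higher number from compound 2 to compound 3 (0.57 log units; beyond the scatter)), and it leaves compound 3 where it cannot be told apart from the cyclopropyl compound (a 1.7-fold lower number from compound 1 to compound 3 (0.22 log units; within the scatter)). The earlier step could be read as a straight chain doing better than cyclopropyl, but this result does not support that reading, since a straight propyl chain alone brings no gain that lies beyond the scatter. Among these three compounds, only the pentyl chain of compound 2 separates from the others, and compound 2 remains the strongest of the three.

With only propyl and pentyl as straight chains, the compounds shown leave open whether the number falls gradually or abruptly between them, which a butyl chain would help to settle, and whether a longer chain such as heptyl would lower it further. They also leave open how a branched chain, or an amine or carboxylic acid at the end of the chain, would behave at this position. Nothing available here explains why the chain length changes the number in this way.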